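This account rests on a few compounds, and the source may have more. Where it says the series, first, only, none or still open, it means among the compounds named here.

In a functional assay on MCF7 cells (Homo sapiens) for antiproliferative activity, read by MTT assay, with a stated time of 24 h (a lower number here means a stronger inhibitor, a higher number a weaker inhibitor), compound 1 `CCCCc1oc2ccccc2c1C(=O)c1ccc(OCC(N)=O)cc1` reads > 50000 nM, which is a limit of the assay and not a number. Among the compounds with values here, compound 2 `CCCCc1oc2ccccc2c1C(=O)c1ccc(OCC(=O)NCc2ccccc2)cc1` gives 19600 nM, the only true number so far. Within the data shown here, the one measured step, an at least 2.5-fold lower number from compound 1 to compound 2 (0.40 log units; beyond the scatter), places benzyl in place of hydrogen on an amide-type nitrogen, and its size rests on (the limit of > 50000 nM in this assay, at which 1 of the 2 values shown sits), so the true gain may be larger. Compound 3 `CCCCNC(=O)CCCOc1ccc(C(=O)c2c(CCCC)oc3ccccc23)cc1` follows from compound 2 through 2-(butylcarbamoyl)ethyl in place of benzylcarbamoyl on a saturated chain carbon bound to an oxygen on an aromatic ring. The same difference reads (benzylcarbamoyl)methyl to 3-(butylcarbamoyl)propyl. The amide-type nitrogen of compound 3 still carries a substituent, so the expectation leans on an at least 2.5-fold lower number from compound 1 to compound 2 (0.40 log units; beyond the scatter), though that step changed neither the chain length nor a benzyl for a butyl. Among the measured compounds shown here, no measured step covers those changes, so the expected step, a 1.0-fold higher number from compound 2 to compound 3 (0.01 log units; within the scatter), is none beyond the scatter in this assay. For compound 3 the estimated value is 20000 nM. The expected range for compound 3 runs from 7000 nM to 50000 nM.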

Compound 3, half-maximal inhibitory concentration: > 50000 nM
Compound 3 was reported as a limit; the forecaster's own chance of this, stated with the estimate: 20%; at least 2.5-fold (0.39 log units) between middle value and limit.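

The step of an at least 2.5-fold higher number from compound 2 to compound 3 (0.40 log units; beyond the scatter) shows that a substituent on the amide-type nitrogen does not by itself secure a measurable reading in this assay, since compound 3 also carries one and yet reads as a limit, not a number. At this place, on a saturated chain carbon bound to an oxygen on an aromatic ring, the reading therefore depends on more than the presence of that substituent, and among the three compounds only compound 2, with its benzylcarbamoyl group and six-membered aromatic ring, gives a true number. The size of this step is only a lower bound, and the step between compound 1 and compound 3 cannot be read at all: the limit of > 50000 nM in this assay, at which 2 of the 3 values shown sit.

The change from (benzylcarbamoyl)methyl to 3-(butylcarbamoyl)propyl alters the chain and the group on the nitrogen together, so the compounds shown cannot assign the loss to either one. From the compounds shown here alone, a (butylcarbamoyl)methyl group or a 3-(benzylcarbamoyl)propyl group at this place would separate the two, while the effect of an amine or a carboxylic acid in place of the amide remains open.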